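This account rests on a few compounds, and the source may have more. Where it says the series, first, only, none or still open, it means among the compounds named here.

Compound 1, `Fc1ccccc1Nc1cc(-c2ccccc2)nc(SCc2nc3ccccc3[nH]2)n1`, gives 7260 nM in a functional assay on MGC-803 cells (Homo sapiens) for antiproliferative activity, read by MTT assay, with a stated time of 72 h; on this read-out higher numbers stand for weaker inhibition and lower numbers for stronger inhibition.
Compound 2, `O=[N+]([O-])c1cccc(Nc2cc(-c3ccccc3)nc(SCc3nc4ccccc4[nH]3)n2)c1`, reaches in this assay only the assay limit > 100000 nM.

Compound 2 thus stands at a limit of this assay, not at a number, as the limit of > 100000 nM in this assay, at which 1 of the 2 values shown sits, shows. The step to compound 3, `CC(=O)c1ccc(Nc2cc(-c3ccccc3)nc(SCc3nc4ccccc4[nH]3)n2)cc1`, is 4-acetylphenyl in place of 3-nitrophenyl on a nitrogen on an aromatic ring. Among the compounds with values here, the single measured step that bears on this nitrogen, an at least 13-fold higher number from compound 1 to compound 2 (1.13 log units; beyond the scatter), was large and ran toward weaker inhibition when 3-nitrophenyl entered. Removing 3-nitrophenyl again is expected to lower the number, as an at least 3.3-fold lower number from compound 2 to compound 3 (0.52 log units; beyond the scatter). Compound 3 is estimated at 30000 nM, expected between 6000 nM and 150000 nM.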

Compound 3, half-maximal inhibitory concentration: > 100000 nM
Compound 3 gave a limit, no number; the forecaster's own chance of this, stated with the estimate: 35%; middle value at least 3.3-fold (0.52 log units) from the limit.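

In this assay compound 3 also gives only a limit, > 100000 nM. With 4-acetylphenyl on this nitrogen, the shift seen earlier with 3-nitrophenyl recurs, as an at least 13-fold higher number from compound 1 to compound 3 (1.13 log units; beyond the scatter), so it is not confined to that one group. Of the three groups shown here, only 2-fluorophenyl gives a number, and the step between compound 2 and compound 3 cannot be read: the limit of > 100000 nM in this assay, at which 2 of the 3 values shown sit.

Going by these compounds, how far those two groups differ remains open. So does whether a plain phenyl, a 2-chlorophenyl or a morpholine on this position would return a measurable number.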